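Three Compounds at the Limit, a Fourth Awaits Its Value

The source may hold more compounds than are shown below. What is called first, only, known or untested is meant among the compounds shown, and "the series" means these compounds.

Compound 3 `CCOC(=O)CNc1ncc([N+](=O)[O-])c(N(CC(=O)OCC)Cc2ccccc2)n1` carries an (ethoxycarbonyl)methyl group on the amine nitrogen of the shared core. In a functional assay on A549 cells (Homo sapiens) for antiproliferative activity, read by MTT assay, with a stated time of 48 h (a lower number here means a stronger inhibitor, a higher number a weaker inhibitor), compound 3 gives only a limit, > 100000 nM. Its two relatives share the same fate. Compound 1 `CCOC(=O)CN(Cc1ccccc1)c1nc(Nc2ccccc2)ncc1[N+](=O)[O-]`, with phenyl on that nitrogen, gives a limit of > 100000 nM in this assay. Compound 2 `CCOC(=O)CN(Cc1ccccc1)c1nc(Nc2cc(OC)c(OC)c(OC)c2)ncc1[N+](=O)[O-]`, with 3,4,5-trimethoxyphenyl there, likewise gives a limit of > 100000 nM. Among the measured compounds shown here, all three values sit at the limit of > 100000 nM in this assay, at which 3 of the 3 values shown sit, so no step among them can be read: a step that the two limits leave unreadable from compound 1 to compound 3 and a step that the two limits leave unreadable from compound 2 to compound 3 are both hidden by the limits, as is a step that the two limits leave unreadable from compound 1 to compound 2.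

Compound 4 `CCOC(=O)CN(Cc1ccccc1)c1nc(Nc2cccc(OC)c2)ncc1[N+](=O)[O-]` differs from compound 3 by 3-methoxyphenyl in place of (ethoxycarbonyl)methyl on a nitrogen on an aromatic ring. The closest measured changes, phenyl and 3,4,5-trimethoxyphenyl in place of (ethoxycarbonyl)methyl on the same nitrogen, both led to limits in this assay, so no direction and no size can be read from them. Compound 4 is therefore expected to give about 100000 nM, somewhere between 20000 nM and 300000 nM. The step is estimated as a number no higher from compound 3 to compound 4 (the limit leaves the size open), with a real chance that only a limit is reported again.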

Compound 4, half-maximal inhibitory concentration: > 100000 nM
Compound 4 ended at the assay's limit; the forecaster's own chance of this, stated with the estimate: 75%; the middle value sits exactly at the limit.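

Compound 4 also gives only a limit in this assay, so no step linking it to compound 1, compound 2 or compound 3 can be read: the limit of > 100000 nM in this assay, at which 4 of the 4 values shown sit.

The compounds shown leave open whether any group on that nitrogen changes the activity in this assay at all.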